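The source may hold more compounds than are shown below. What is called first, only, known or untested is meant among the compounds shown, and "the series" means these compounds.

Working notes on the series in a functional assay on CWR22R cells (Homo sapiens) for antiproliferative activity, read by propidium iodide staining, with a stated time of 96 h; on this read-out higher numbers stand for weaker inhibition and lower numbers for stronger inhibition: compound 1 `CC(O)(CSc1ccc(S(F)(F)(F)(F)F)cc1)C(=O)Nc1ccc(S(F)(F)(F)(F)F)cc1` gives 24400 nM, compound 2 `CC(O)(CSc1ccc(F)cc1)C(=O)Nc1ccc(S(F)(F)(F)(F)F)cc1` gives 13500 nM, and compound 3 `CC(O)(CSc1ccc(C(F)(F)F)cc1)C(=O)Nc1ccc(S(F)(F)(F)(F)F)cc1` gives 14800 nM. Compound 3 therefore stands within the scatter of both other compounds. Compound 4 `CC(O)(CSc1ccc(OC(F)(F)F)cc1)C(=O)Nc1ccc(S(F)(F)(F)(F)F)cc1` differs from it by trifluoromethoxy in place of trifluoromethyl on an aromatic carbon, with trifluoromethoxy in place of trifluoromethyl on an aromatic carbon, para to a large group. Three measured swaps on an aromatic carbon bear on this change: a 1.8-fold lower number from compound 1 to compound 2 (0.26 log units; within the scatter), a 1.6-fold lower number from compound 1 to compound 3 (0.22 log units; within the scatter) and a 1.1-fold higher number from compound 2 to compound 3 (0.04 log units; within the scatter). None leaves the scatter, so no step beyond the scatter is expected in this assay. The expected step is a 1.0-fold higher number from compound 3 to compound 4 (0.01 log units; within the scatter). Compound 4 is estimated at 15000 nM, with an expected range of 9000 nM to 25000 nM.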

Compound 4, half-maximal inhibitory concentration: 14900 nM
Compound 4: middle estimate off by 1.0-fold (0.00 log units), on the high side; low and high end bracket the measured number.
By their numbers in this assay, from the lowest: compounds 2, 3, 4 and 1 (each within the scatter of the next).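

At this position, on an aromatic carbon para to a large group, trifluoromethoxy joins the swaps that stay inside the scatter in this assay: a 1.0-fold higher number from compound 3 to compound 4 (0.00 log units; within the scatter) and a 1.1-fold higher number from compound 2 to compound 4 (0.04 log units; within the scatter) and a 1.6-fold lower number from compound 1 to compound 4 (0.21 log units; within the scatter). Entry of the oxygen, with its hydrogen-bond acceptor, therefore brings no step beyond the scatter, and all four groups shown here lie within it of one another. No measurement at hand offers a reason for this flat picture.

As far as these compounds go, whether an amine or a carboxylic acid at this position would leave the scatter stays open. So does whether a hydroxyl group here, with its hydrogen-bond donor, would do so.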